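From 2-fluorophenyl to thiophen-2-yl on a sulfonyl sulfur

This account rests on a few compounds, and the source may have more. Where it says the series, first, only, none or still open, it means among the compounds named here.

In an ADME assay on HEK293 cells (Homo sapiens) for cytotoxicity, read by resazurin assay, with a stated time of 48 h (a lower number here means that less compound is tolerated, a higher number that more compound is tolerated), compound 1 `Cc1ccccc1S(=O)(=O)Nc1ccc2oc(-c3ccccc3)nc2c1` gives 57000 nM and compound 2 `O=S(=O)(Nc1ccc2oc(-c3ccccc3)nc2c1)c1ccccc1F` gives 72000 nM so compound 2 stands level with compound 1 within the scatter. Compound 3 `O=S(=O)(Nc1ccc(-c2nc3ccccc3o2)cc1)c1cccs1` returns only a limit in this assay (> 100000 nM). In compound 4 `O=S(=O)(Nc1ccc2oc(-c3ccccc3)nc2c1)c1cccs1` thiophen-2-yl stands in place of the 2-fluorophenyl of compound 2 on a sulfonyl sulfur (thiophen-2-yl in place of 2-fluorophenyl on a sulfonyl sulfur). Going by the values given here, the only measured step, fluoro in place of methyl on an aromatic carbon (a 1.3-fold higher number from compound 1 to compound 2 (0.10 log units; within the scatter)), stayed small, so no shift beyond the scatter is expected in this assay for this change. The expected step is small (a 1.1-fold higher number from compound 2 to compound 4 (0.05 log units; within the scatter)). For compound 4 the estimate is 80000 nM with an expected range from 45000 nM to 130000 nM in all.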

Compound 4, half-maximal cytotoxic concentration: 97000 nM
Beside the measured number, compound 4's estimate is 1.2-fold (0.08 log units) below it, and the stated range covers the measured number.
By their numbers in this assay, from the lowest: compounds 1, 2 and 4 (each within the scatter of the next). At a limit, above all of these: compound 3.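

In this assay, thiophen-2-yl on the sulfonyl sulfur gives no shift beyond the scatter against either six-membered aromatic ring: a 1.3-fold higher number from compound 2 to compound 4 (0.13 log units; within the scatter), and a 1.7-fold higher number from compound 1 to compound 4 (0.23 log units; within the scatter). This position has now taken three aromatic groups, one of them with a ring sulfur, without the number leaving the scatter. Compound 3 returns only a limit of the assay, not a number: the limit of > 100000 nM in this assay, at which 1 of the 4 values shown sits.

As far as these compounds go, whether an amine, a carboxylic acid or a short alkyl chain in place of the aromatic ring on the sulfonyl sulfur would move the number beyond the scatter stays open.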